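Cinnamoyl hydrazide series: methyl for bromine on the phenyl

The source may hold more compounds than are shown below. What is called first, only, known or untested is meant among the compounds shown, and "the series" means these compounds.

For the measured compounds named here, the three measured members share one core and differ only in the aryl group on the double-bonded chain. In a functional assay on cells (Cancer cell lines, Homo sapiens) for inhibition, read by MTT assay, with a stated time of 48 h (a lower number here means a stronger inhibitor, a higher number a weaker inhibitor), compound 1 `Cc1ccc(/C=C/C(=O)NNC(=O)c2ccc3c(c2)OCCO3)cc1` gives 1050 nM, compound 2 `O=C(/C=C/c1cccc(Br)c1)NNC(=O)c1ccc2c(c1)OCCO2` gives 3330 nM, and compound 3 `O=C(/C=C/c1ccccc1F)NNC(=O)c1ccc2c(c1)OCCO2` gives 4510 nM. Compound 2 thus stands second highest of the three numbers: its nearest neighbour is compound 3, with a 1.4-fold higher number from compound 2 to compound 3 (0.13 log units; within the scatter), while compound 1 lies furthest, with a 3.2-fold higher number from compound 1 to compound 2 (0.50 log units; beyond the scatter).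

Compound 4 `Cc1ccccc1/C=C/C(=O)NNC(=O)c1ccc2c(c1)OCCO2` is not yet measured. Relative to compound 2 the change is 2-methylphenyl in place of 3-bromophenyl on a double-bonded chain carbon bound to a double-bonded chain carbon.

Going by the values given here, two measured steps bear on this. Both departures from 4-methylphenyl raised the number modestly: a 3.2-fold higher number from compound 1 to compound 2 (0.50 log units; beyond the scatter) and a 4.3-fold higher number from compound 1 to compound 3 (0.63 log units; beyond the scatter). Between the two halogenated members the difference was small, a 1.4-fold higher number from compound 2 to compound 3 (0.13 log units; within the scatter), so the bromine-bearing and fluorine-bearing aryls cannot be told apart here. Compound 4 brings back a methyl group, as in compound 1, but as 2-methylphenyl rather than 4-methylphenyl; compound 3, whose substituent is also on a 2-position, sat high. The expectation is therefore a step toward compound 1 but not all the way, with a 1.7-fold lower number from compound 2 to compound 4 (0.22 log units; within the scatter) expected.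

For compound 4 in this assay the estimate is 2000 nM, with a range of 900 nM to 4500 nM.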

Compound 4, half-maximal inhibitory concentration: 7710 nM
Beside the measured number, compound 4's estimate is 3.9-fold (0.59 log units) below it; the measured number lies above the stated range.
By their numbers in this assay, from the lowest: compound 1; then compounds 2, 3 and 4 (each within the scatter of the next, the first and the last beyond it).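

In this assay, the methyl group alone does not preserve the low number of compound 1: 2-methylphenyl in place of 4-methylphenyl gives a clear loss (a 7.3-fold higher number from compound 1 to compound 4 (0.87 log units; beyond the scatter)), so within this pair the number depends on where the methyl sits on the aryl. Compound 1 is now beyond the scatter of all three other members, making its 4-methylphenyl the strongest aryl among the four, while 2-methylphenyl in place of 3-bromophenyl also raises the number (a 2.3-fold higher number from compound 2 to compound 4 (0.36 log units; beyond the scatter)). Methyl in place of fluoro on an aromatic carbon (a 1.7-fold higher number from compound 3 to compound 4 (0.23 log units; within the scatter)) stays within the scatter, so 2-fluorophenyl and 2-methylphenyl cannot be told apart here, and no supporting measurement is available to account for any of these differences.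

Still open, as far as these compounds go, is whether the low number of compound 1 belongs to the methyl itself or to any group placed as in 4-methylphenyl, a question that 4-bromophenyl, 4-fluorophenyl or 3-methylphenyl would address directly. The compounds shown also leave open how an aryl bearing an amine, a carboxylic acid or a longer chain would read on this double-bonded chain carbon.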